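A few compounds are considered here, and "the series" means these few. Any claim that something is new, unique, unknown or untested is made for them only; others in the source may bear on it.

Working notes on the series. In a functional assay on DU-145 cells (Homo sapiens) for cytotoxicity, read by trypan blue exclusion, with a stated time of 96 h (a lower number here means a stronger inhibitor, a higher number a weaker inhibitor), compound 1 `COC(=O)C(Nc1cc(NS(=O)(=O)/C=C/c2c(OC)cc(OC)cc2OC)ccc1OC)c1ccccc1` gives 2500 nM and compound 2 `COc1cc(OC)c(/C=C/S(=O)(=O)Nc2ccc(OC)c(NCC(=O)O)c2)c(OC)c1` gives 400 nM while compound 3 `COc1cc(OC)c(/C=C/S(=O)(=O)Nc2ccc(OC)c(NC(C(=O)O)c3ccccc3)c2)c(OC)c1` stands lowest of the three at 75 nM with both gaps beyond the scatter. The next structure is compound 4 `COc1cc(OC)c(/C=C/S(=O)(=O)Nc2ccc(OC)c(NC(C(=O)O)c3ccc(F)cc3)c2)c(OC)c1` and its difference from compound 3 is fluoro in place of hydrogen on an aromatic carbon which reads as phenyl to 4-fluorophenyl. Among the measured compounds shown here, two measured steps bear on this. Phenyl in place of hydrogen on the chain carbon goes with a 5.3-fold lower number from compound 2 to compound 3 (0.73 log units; beyond the scatter) as a modest step, and removal of the methyl from the ester goes with a 33-fold lower number from compound 1 to compound 3 (1.52 log units; beyond the scatter) as a large one. For the measured compounds named here, neither step varies a substituent on the phenyl ring, and no fluoro compound has yet been measured in this assay for comparison. Compound 4 keeps both the phenyl ring and the free acid, so a step within the scatter is expected, with no firm direction. The estimated change is a 1.1-fold higher number from compound 3 to compound 4 (0.03 log units; within the scatter) and it remains an expectation only. Compound 4 is expected at 80 nM within an estimated range of 30 nM to 220 nM for this measurement.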

Compound 4, half-maximal inhibitory concentration: 75 nM
Estimate against measurement, compound 4: 1.1-fold (0.03 log units) above; measured number inside the range.
By their numbers in this assay, from the lowest: compounds 3 and 4 (each within the scatter of the next); then compound 2; then compound 1.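

In this assay, fluoro in place of hydrogen on the aromatic carbon para to a large group is accommodated, with no change at the digits printed from compound 3 to compound 4 (within the scatter), so this position of the phenyl ring takes a fluorine with no step beyond the scatter. The lower numbers seen earlier for the unsubstituted phenyl acid also hold with the fluorinated ring: 4-fluorophenyl in place of hydrogen on the chain carbon gives a 5.3-fold lower number from compound 2 to compound 4 (0.73 log units; beyond the scatter), and the change on the nitrogen to carboxy(4-fluorophenyl)methyl gives a 33-fold lower number from compound 1 to compound 4 (1.52 log units; beyond the scatter). No supporting data bear on why the number stays put with this change. The compounds shown leave open whether chloro, methoxy or trifluoromethyl at this same ring position would hold the number. Also open, going by these compounds, is whether an amide in place of the carboxylic acid would keep it.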